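The source may hold more compounds than are shown below. What is called first, only, known or untested is meant among the compounds shown, and "the series" means these compounds.

Three close relatives have been tested in a functional assay on HeLa cells (Homo sapiens) for antiproliferative activity, read by MTT assay, with a stated time of 48 h; a higher number here means a weaker inhibitor, a lower number a stronger inhibitor. Compound 1 `Brc1ccc(CSc2nnc(-c3cnccn3)o2)cc1` gives 21600 nM, and compound 2 `c1ccc(CSc2nnc(-c3cnccn3)o2)cc1` gives 21100 nM. The only difference between these two is hydrogen in place of bromo on an aromatic carbon, and the step it made was a 1.0-fold lower number from compound 1 to compound 2 (0.01 log units; within the scatter). Compound 3 `Brc1ccc(CSc2nnc(-c3cnccn3)s2)cc1` carries a different core; the difference between the two cores is not broken down here. In this assay compound 3 gives 12400 nM, a number within the scatter of the other two.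

Compound 4 `c1ccc(CSc2nnc(-c3cnccn3)s2)cc1` has not yet been measured. It differs from compound 3 by hydrogen in place of bromo on an aromatic carbon, which is the same change that was made from compound 1 to compound 2, at the same kind of place, so this change occurs twice among the four compounds. Because a 1.0-fold lower number from compound 1 to compound 2 (0.01 log units; within the scatter) shows that the first such change left the number essentially unchanged, a similar outcome is expected for the second. For compound 4 the expected step is a 1.0-fold lower number from compound 3 to compound 4 (0.01 log units; within the scatter). Compound 4 is therefore estimated at 12000 nM, with a likely range from 5000 nM to 30000 nM.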

Compound 4, half-maximal inhibitory concentration: 34400 nM
Compound 4: the middle estimate sits 2.9-fold (0.46 log units) below what was measured; measured number outside the range, above it.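

In this assay, hydrogen in place of bromo gave a 2.8-fold higher number from compound 3 to compound 4 (0.44 log units; beyond the scatter), and this modest step does not match the one seen on the other core: the same change on two cores in this assay, a 1.0-fold lower number (0.01 log units; within the scatter) from compound 1 to compound 2 and a 2.8-fold higher number (0.44 log units; beyond the scatter) from compound 3 to compound 4, 2.8-fold (0.45 log units) apart, beyond the scatter of two such steps. In this series, then, the result of this change cannot simply be carried from one core to the other: the near absence of a step on the core of compound 1 gave no warning of the weaker number on the core of compound 3. Among these compounds, with only one pair on each core, this does not show why the two cores differ, nor does it establish a general rule for either core.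

The compounds shown leave open how other groups on the same aromatic carbon, such as chloro, methoxy or an amine, would behave on each core. They also leave open whether any such group would give a similar step on both cores or again separate them.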